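Methoxy to hydroxy on the core of compound 1

The compounds below may be only part of what the source reports. "The series", "measured", "known", "first", "only" and "open" are said of these compounds alone.

compound 1, `CCCCOc1ccc(C(=O)n2c(C)c(CC(=O)O)c3cc(OC)ccc32)cc1` — in an assay on isolated protein for binding affinity to prostaglandin E2 receptor EP4 subtype (Mus musculus) (a higher number here means a weaker inhibitor, a lower number a stronger inhibitor), only a limit: > 10000 nM
compound 2, `CCCCOc1ccc(C(=O)n2c(C)c(CCCCC(=O)O)c3cc(OC)ccc32)cc1` — in this assay: 4200 nM

Compound 1 stands at the edge of what this assay reports; its value is a limit and not a number, and the limit of > 10000 nM in this assay, at which 1 of the 2 values shown sits, shows that one of the two measured values sits there. Within the data shown here, compound 2 is the only compound with a number, and the difference between the two is an extension of the chain, giving an at least 2.3-fold lower number from compound 1 to compound 2 (0.37 log units; beyond the scatter). That step changes the chain length only and says nothing about the oxygen on the ring.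

Compound 3, `CCCCOc1ccc(C(=O)n2c(C)c(CC(=O)O)c3cc(O)ccc32)cc1`, differs from compound 1 by hydrogen in place of methyl on an oxygen on an aromatic ring. Among the measured compounds shown here, no measured step in this set touches this position, so there is nothing to indicate a direction, and the expected step is a step that the limit leaves unreadable from compound 1 to compound 3, nothing beyond the scatter. Since compound 1 is itself a limit, compound 3 is expected most likely to return a limit as well. For compound 3 the estimate is 15000 nM, with a range from 5000 nM to 50000 nM.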

Compound 3, inhibition constant: > 10000 nM
Compound 3: no number, only a limit; the forecaster's own chance of this, stated with the estimate: 70%; the middle value is on the limit's open side.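

In this assay compound 3 gives > 10000 nM, a limit and not a number. Compound 1 also gives only a limit, so no step can be read between compound 1 and compound 3: the limit of > 10000 nM in this assay, at which 2 of the 3 values shown sit.

The compounds shown leave open whether methoxy to hydroxy changes the number in this assay at all, and in which direction.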